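Swapping the amino for a chloro on the phenol ring

A few compounds are considered here, and "the series" means these few. Any claim that something is new, unique, unknown or untested is made for them only; others in the source may bear on it.

Of the compounds shown here, three with a shared core have been tested in an assay for inhibition of Indoleamine 2,3-dioxygenase 1 (Homo sapiens), with a stated time of 1 h, tested at 10 uM; a lower number here means less inhibition, a higher number more inhibition at the concentration tested (going by the name of the read-out). Compound 1 `Nc1cccc(CNc2cc(Br)cc3[nH]ncc23)c1` gives 31%. Compound 2 `Oc1ccc(CNc2cc(Br)cc3[nH]ncc23)cc1O` gives 50%. Compound 3 `Nc1cc(CNc2cc(Br)cc3[nH]ncc23)ccc1O` gives 32%, which places it second highest of the three: the step of a number 1 percentage points higher from compound 1 to compound 3 (within the scatter) leaves compounds 1 and 3 indistinguishable, while the step of a number 18 percentage points lower from compound 2 to compound 3 (beyond the scatter) sets compound 3 clearly under compound 2.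

Compound 4 `Oc1ccc(CNc2cc(Br)cc3[nH]ncc23)cc1Cl` differs from compound 3 in one place: chloro in place of amino on an aromatic carbon The chloro sits ortho to a hydroxy group, where the amino stood. Within the data shown here, two measured steps bear on this. The step of a number 18 percentage points lower from compound 2 to compound 3 (beyond the scatter) shows that an amino in place of a hydroxy lowered inhibition modestly, so removing the amino may give some of that back. The step of a number 1 percentage points higher from compound 1 to compound 3 (within the scatter) shows that adding a hydroxy alone changed nothing beyond the scatter. Among the measured compounds shown here, no measured step involves a chloro. A small rise is therefore expected, a number 10 percentage points higher from compound 3 to compound 4 (within the scatter), and compound 4 is estimated at 42%, within a range from 22% to 62%.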

Compound 4, a percentage reported as inhibition, at one concentration (the size of the read-out at that concentration, not a potency): 60%
Estimate against measurement, compound 4: 18 percentage points below; measured number inside the range.
By their numbers in this assay, from the lowest: compounds 1 and 3 (each within the scatter of the next); then compounds 2 and 4 (each within the scatter of the next).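

In this assay, this position, ortho to a hydroxy group, responds clearly to the group it carries: chloro in place of amino gives a number 28 percentage points higher from compound 3 to compound 4 (beyond the scatter). Chloro in place of hydroxy gives a number 10 percentage points higher from compound 2 to compound 4 (within the scatter), so those two groups cannot be told apart here, and amino is the only one of the three that stands clearly lower. Nothing measured explains why amino differs from the other two groups at this position.

On these data alone, it remains open whether other groups here, such as fluoro, bromo, methyl or methoxy, would match chloro and hydroxy or fall to the level of amino. As far as these compounds go, it is also open whether compound 4 would keep its inhibition if a methoxy replaced the hydroxy group that stays on its ring.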